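This account rests on a few compounds, and the source may have more. Where it says the series, first, only, none or still open, it means among the compounds named here.

Of the compounds shown here, three built on one shared core have been tested on human lung cells. Compound 1 `CCCCOc1ccc(-c2nc3ncccn3c2NC2CCCCCC2)cc1` carries a cycloheptyl group on the ring nitrogen; in a toxicity assay on A549 cells (Homo sapiens) for cytotoxicity, read by luminescence and CellTiter-Glo, with a stated time of 48 h (a higher number here means that more compound is tolerated, a lower number that less compound is tolerated), compound 1 gives 26000 nM. Compound 2 `CCCCOc1ccc(-c2nc3ncccn3c2NCCC)cc1` carries propyl there instead. In this assay compound 2 reaches only the limit of > 100000 nM, which is not a number. Compound 3 `CCCCOc1ccc(-c2nc3ncccn3c2Nc2ccc(F)cc2)cc1` carries 4-fluorophenyl. In this assay compound 3 also sits at the limit of > 100000 nM, so for compound 3 only a lower bound is known. The steps of an at least 3.8-fold higher number from compound 1 to compound 2 (0.58 log units; beyond the scatter) and an at least 3.8-fold higher number from compound 1 to compound 3 (0.58 log units; beyond the scatter) both show that replacing the cycloheptyl group raised the tolerated concentration, while the step that the two limits leave unreadable from compound 2 to compound 3 cannot be read because the limit of > 100000 nM in this assay, at which 2 of the 3 values shown sit, caps both values.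

Compound 4 `CCCCOc1ccc(-c2nc3ncccn3c2NCc2ccco2)cc1` has not been measured. Its change from compound 3 is (furan-2-yl)methyl in place of 4-fluorophenyl on a nitrogen on an aromatic ring. Both earlier replacements of cycloheptyl ended at the limit, so compound 4 is expected to behave alike, and the step of a number no higher from compound 3 to compound 4 (the limit leaves the size open) is expected to stay within the scatter. Compound 4 is therefore estimated at 100000 nM, within a range from 35000 nM to 300000 nM.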

Compound 4, half-maximal cytotoxic concentration: 78000 nM
Beside the measured number, compound 4's estimate is 1.3-fold (0.11 log units) above it; measured number inside the range.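

Among the compounds shown here, compound 4 is the first replacement of cycloheptyl on this nitrogen to give a real number rather than a limit in this assay, and a 3.0-fold higher number from compound 1 to compound 4 (0.48 log units; beyond the scatter) shows the size of such a change for the first time. Against the other two replacements, an at least 1.2-fold lower number from compound 3 to compound 4 (0.10 log units; that floor lies within the scatter) and an at least 1.2-fold lower number from compound 2 to compound 4 (0.10 log units; that floor lies within the scatter) are floors that do not leave the scatter, so compound 4 cannot be ranked against either. Those steps cannot be read any further, and the step between compound 2 and compound 3 cannot be read at all, because of one shared cap: the limit of > 100000 nM in this assay, at which 2 of the 4 values shown sit.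

Among the compounds shown, only cycloheptyl gives a clearly lower number, and a single compound cannot show whether that belongs to saturated rings in general. On these data alone, whether cyclopentyl, cyclohexyl or benzyl on the same nitrogen would fall nearer compound 1 or compound 4 stays open.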